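Propargyl Ether to Prenyl Ether on a Weakly Cytotoxic Scaffold

The source may hold more compounds than are shown below. What is called first, only, known or untested is meant among the compounds shown, and "the series" means these compounds.

Measured compounds:
compound 1 `C#CCOc1ccc(/C=C/C(=O)c2cccn2C)cc1OC` — > 50000 nM
compound 2 `C#CCOc1ccc(/C=C/C(=O)c2ccc(CC=C(C)C)cc2)cc1OC` — > 50000 nM
compound 3 `C#CCOc1ccc(C(C)=O)cc1CC=C` — 38200 nM

All three compounds were tested in a functional assay on CCRF-CEM cells (Homo sapiens) for cytotoxicity, with a stated time of 72 h; on this read-out lower numbers stand for stronger inhibition and higher numbers for weaker inhibition. For compound 1 the value > 50000 nM is a limit of the assay, not a measured number. For compound 2 the value > 50000 nM is likewise a limit. Among the measured compounds shown here, compound 3 is the only one of the three with an actual number, giving 38200 nM in this assay; it therefore stands apart from the other two simply in being quantifiable, as the limit of > 50000 nM in this assay, at which 2 of the 3 values shown sit, shows, and no step between measured compounds can be drawn from these three.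

Compound 4 `C=CCc1cc(C(C)=O)ccc1OCC=C(C)C` differs from compound 3 in a single place: 2-methylprop-1-en-1-yl in place of ethynyl on a saturated chain carbon bound to an oxygen on an aromatic ring. For the measured compounds named here, no measured step describes such a change here. The expectation rests only on compound 3 itself. The exchange keeps the rest of the molecule untouched, so a step no larger than the usual scatter is expected, and the expected step from compound 3 to compound 4 is a 1.0-fold higher number from compound 3 to compound 4 (0.02 log units; within the scatter). Compound 4 is thus expected to give about 40000 nM in this assay, within a range from 15000 nM to 110000 nM, with a real chance that only a limit is reported.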

Compound 4, half-maximal inhibitory concentration: 16300 nM
Beside the measured number, compound 4's estimate is 2.5-fold (0.39 log units) above it; measured number inside the range.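

In this assay, replacing propargyl with 3-methylbut-2-en-1-yl gives a 2.3-fold lower number from compound 3 to compound 4 (0.37 log units; beyond the scatter) and leaves the rest of the molecule untouched. This is the only comparison shown between two compounds that differ in one place, and the step is modest but beyond the usual scatter. It shows that the group on this oxygen, which is bound to an aromatic ring, can change the number in this assay, although the data shown offer no measured explanation for the step.

Two changes arrive together in this exchange, as a triple bond leaves and a longer, branched chain with a double bond enters, so a saturated pentyl chain on the same oxygen would help to separate them. As far as these compounds go, it also remains open whether the same exchange would carry over to the cores of compound 1 and compound 2, and whether an amine at the end of the chain would move the number further in either direction.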